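The source may report more compounds than this note shows. Statements on the series, on what has been measured and on what is new or still open speak of the compounds shown alone.

Measured compounds:
compound 1 `CN(C(=O)C[C@@H](N)CCCCN)C1CN=C(NC(N)=O)NC1=O`
compound 2 `CN(C(=O)C[C@@H](N)CCCCN)C1CN=C(Nc2ccccn2)NC1=O`
compound 3 `CN(C(=O)C[C@@H](N)CCCCN)C1CN=C(Nc2cnccn2)NC1=O`

In a functional assay for inhibition, with Oryctolagus cuniculus as the target (a higher number here means a weaker inhibitor, a lower number a stronger inhibitor), compound 1 gives 2800 nM. In the same assay compound 2 gives 200 nM. For compound 3 this assay reports only a limit, < 100 nM; this is one of the values sitting at the limit of < 100 nM in this assay, at which 1 of the 3 values shown sits.

Among the two plain numbers, compound 2 holds the lower one, the nearest being compound 1: a 14-fold lower number from compound 1 to compound 2 (1.15 log units; beyond the scatter). The other measured steps, an at least 28-fold lower number from compound 1 to compound 3 (1.44 log units; beyond the scatter) and an at least 2.0-fold lower number from compound 2 to compound 3 (0.30 log units; that floor lies within the scatter), likewise change only the group on the amine nitrogen of the shared core.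

Compound 4 `CN(C(=O)C[C@@H](N)CCCN=C(N)N)C1CN=C(Nc2ccccn2)NC1=O` differs from compound 2 in another part of the molecule: a group of 4 heavy atoms (1 carbon, 3 nitrogen; no ring) in place of a group of 2 heavy atoms (1 carbon, 1 nitrogen; no ring), on a saturated chain carbon, four bonds along the chain from an amine nitrogen. Within the data shown here, none of the measured steps touches this chain end, so nothing measured bears directly on the change. Among the measured compounds shown here, with no measured precedent, the expectation is a step of about no change at the digits printed from compound 2 to compound 4 (within the scatter), that is, none beyond the scatter. Compound 4 is therefore estimated at 200 nM in this assay, within a range of 70 nM to 600 nM.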

Compound 4, half-maximal inhibitory concentration: 70 nM
For compound 4 the middle estimate is 2.9-fold (0.46 log units) above the measured one; the range from low to high includes it.
By their numbers in this assay, from the lowest: compound 4; then compound 2; then compound 1.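

In this assay, among these compounds, the end of the chain now proves to count as well: the earlier steps changed only the group on the amine nitrogen of the shared core, whereas here, with pyridin-2-yl held fixed, the group of 4 heavy atoms in place of aminomethyl gives a 2.9-fold lower number from compound 2 to compound 4 (0.46 log units; beyond the scatter) as a modest step. Both parts of the molecule therefore move the number, though for this chain end the reading rests on a single pair of compounds. Nothing at hand accounts for the step at this chain end.

From the compounds shown here alone, how this chain end behaves together with pyrazin-2-yl on the amine nitrogen remains open. So does the response at this place, on the saturated chain carbon, to a carboxylic acid, a simple methylamine or a longer chain carrying the same end group.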